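Amidoxime in Place of Aldoxime on a Shared Core

The compounds below may be only part of what the source reports. "The series", "measured", "known", "first", "only" and "open" are said of these compounds alone.

Measured compounds:
compound 1 `O/N=C/c1ccc(Sc2cc(F)cc(C3CCOCC3)c2)cc1` — 120 nM
compound 2 `COC1(c2cc(F)cc(Sc3ccc4c(c3)OCC/C4=N\O)c2)CCOCC1` — 50 nM

Of the compounds shown here, two have been measured in a functional assay (blood) for inhibition, with Homo sapiens as the target; a lower number here means a stronger inhibitor, a higher number a weaker inhibitor. Compound 1 gives 120 nM, the highest of the two numbers; compound 2 gives 50 nM, a lower number, and the gap between the two lies beyond the usual scatter. Compound 3 `CN(C)/C(=N\O)c1ccc(Sc2cc(F)cc(C3CCOCC3)c2)cc1` is not yet measured. It differs from compound 1 by a group of 6 heavy atoms (3 carbon, 2 nitrogen, 1 oxygen; no ring) in place of a group of 3 heavy atoms (1 carbon, 1 nitrogen, 1 oxygen; no ring), on an aromatic carbon, on an aromatic carbon of a six-membered aromatic ring of carbon only. Within the data shown here, no step between two measured compounds shows what such a change does, so the direction is open. With the change confined to one end of the core and no more than a modest step expected in either direction, compound 3 is estimated at 150 nM, within 50 nM to 500 nM, a change of a 1.3-fold higher number from compound 1 to compound 3 (0.10 log units; within the scatter) that is expected to stay close to the scatter.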

Compound 3, half-maximal inhibitory concentration in the Homo sapiens assay: 280 nM
Estimate against measurement, compound 3: 1.9-fold (0.27 log units) below; measured number inside the range.
By their numbers in the Homo sapiens assay, from the lowest: compound 2; then compound 1; then compound 3.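

In the Homo sapiens assay the swap gives a 2.3-fold higher number from compound 1 to compound 3 (0.37 log units; beyond the scatter), which shows that this end of the shared core responds to what is placed on it, and that here the group of 6 heavy atoms goes with a weaker inhibitor than the group of 3 heavy atoms. The same swap leaves the proton given up far less readily in a physicochemical assay for acid dissociation: the measured acid dissociation constant of compound 1, 10.7, and of compound 3, 14.1, a number 3.40 log units higher (beyond the scatter) In the physicochemical assay compound 1 gives 10.7 and compound 3 gives 14.1. With the heavy-atom count and this measured number shifting together, a single step cannot say which of the two, if either, lies behind the higher number in the Homo sapiens assay.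

Open, as far as these compounds go, is how a plain amine or a methyl group on the same carbon would compare with compound 1 and compound 3 in the Homo sapiens assay. Also open, from the compounds shown here alone, is whether the same swap would have a similar effect on the core of compound 2.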